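Urea Aryl Swap on the Shared Pyrimidine-Free Core Series

The source may hold more compounds than are shown below. What is called first, only, known or untested is meant among the compounds shown, and "the series" means these compounds.

Measured so far:
compound 1, `CCc1ccc(Nc2cc(NC(=O)Nc3cc(OC)cc(OC)c3)ncn2)cc1`, 50.1%
compound 2, `COc1ccc(Br)cc1Nc1cc(NC(=O)Nc2c(Cl)cccc2Cl)ncn1`, 33%

In a functional assay on NCI-H226 cells (Homo sapiens) for inhibition, read by MTT assay, with a stated time of 48 h, tested at 10 uM (a higher number here means more inhibition at the concentration tested (going by the name of the read-out), a lower number less inhibition), compound 2 gives the lowest of the two numbers; its nearest neighbour is compound 1, which sits higher by a gap beyond the usual scatter. Compound 3, `COc1cc(NC(=O)Nc2cc(Nc3cc(Br)ccc3OC)ncn2)cc(OC)c1`, has not been measured. It differs from compound 2 in one place: 3,5-dimethoxyphenyl in place of 2,6-dichlorophenyl on an amide-type nitrogen. For the measured compounds named here, no step between measured compounds separates this change from the rest, so its size is open; the account expects the step from compound 2 to compound 3 to be upward by a number 9 percentage points higher from compound 2 to compound 3 (within the scatter), toward the level of compound 1. Compound 3 is estimated at 42%, within 25% to 60%.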

Compound 3, a percentage reported as inhibition, at one concentration (the size of the read-out at that concentration, not a potency): 42.7%
For compound 3 the middle estimate is 0.7 percentage points below the measured one, and the stated range covers the measured number.
By their numbers in this assay, from the lowest: compounds 2, 3 and 1 (each within the scatter of the next, the first and the last beyond it).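

In this assay the urea aryl swap can now be read on its own: 3,5-dimethoxyphenyl in place of 2,6-dichlorophenyl on an amide-type nitrogen gives a number 9.7 percentage points higher from compound 2 to compound 3 (within the scatter) for this one change. With 3,5-dimethoxyphenyl held fixed, 5-bromo-2-methoxyphenyl in place of 4-ethylphenyl on a nitrogen on an aromatic ring gives a number 7.4 percentage points lower from compound 1 to compound 3 (within the scatter), so neither single change stands clear of the scatter. No measurement at hand accounts for either step. From the compounds shown here alone, whether an amine-bearing or carboxylic acid-bearing phenyl on the amide-type nitrogen would move the number beyond the scatter remains open.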